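A few compounds are considered here, and "the series" means these few. Any claim that something is new, unique, unknown or untested is made for them only; others in the source may bear on it.

In a functional assay on KB cells (Homo sapiens) for cytotoxicity, read by sulforhodamine B assay (on this read-out higher numbers stand for weaker inhibition and lower numbers for stronger inhibition), compound 1 `C=C1[C@@H](OC(C)=O)C[C@@H]2[C@](C)(COC=O)[C@H](OC(C)=O)CC[C@@]2(C)[C@@H]1C[C@@H](Nc1ccc(O)cc1)C1=CCOC1=O` gives 28900 nM and compound 2 `C=C1[C@@H](OC(C)=O)C[C@@H]2[C@](C)(COC=O)[C@H](OC(C)=O)CC[C@@]2(C)[C@@H]1C[C@@H](Nc1ccc(OC)cc1)C1=CCOC1=O` gives 32700 nM and so sits level with it, within the scatter. Compound 3 `C=C1[C@@H](OC(C)=O)C[C@@H]2[C@](C)(COC=O)[C@H](OC(C)=O)CC[C@@]2(C)[C@@H]1C[C@@H](Nc1cccc2ccccc12)C1=CCOC1=O` has naphthalen-1-yl in place of 4-methoxyphenyl on an amine nitrogen. For the measured compounds named here, the only measured step (a 1.1-fold higher number from compound 1 to compound 2 (0.05 log units; within the scatter)) places methyl on an oxygen on the aromatic ring and leaves the ring itself unchanged, so it bears only weakly on this replacement. No shift beyond the scatter is expected in this assay on this thin evidence, and no direction can be called. The expected change is small (a 1.2-fold lower number from compound 2 to compound 3 (0.08 log units; within the scatter)). Compound 3 is estimated at 27000 nM (range 11000 nM to 65000 nM).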

Compound 3, half-maximal inhibitory concentration: 32300 nM
Estimate against measurement, compound 3: 1.2-fold (0.08 log units) below; the measured number falls inside the stated range.
By their numbers in this assay, from the lowest: compounds 1, 3 and 2 (each within the scatter of the next).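

In this assay the aromatic group on the amine nitrogen can now be changed in the ring itself, not only at its oxygen, with no shift beyond the scatter: naphthalen-1-yl in place of 4-methoxyphenyl gives a 1.0-fold lower number from compound 2 to compound 3 (0.01 log units; within the scatter) and naphthalen-1-yl in place of 4-hydroxyphenyl gives a 1.1-fold higher number from compound 1 to compound 3 (0.05 log units; within the scatter). A second six-membered aromatic ring and the loss of the ring oxygen thus leave the number level in both steps. Open, on these data alone, is whether a cyclohexyl group or a longer alkyl chain on this nitrogen, or a carboxylic acid on the aromatic ring, would move the number beyond the scatter. No supporting data bear on this result.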